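Phenyl on the saturated ring carbon of the shared core

The compounds below may be only part of what the source reports. "The series", "measured", "known", "first", "only" and "open" are said of these compounds alone.

Of the compounds shown here, two have been tested. Compound 1 `O=C1CC(c2ccccc2)Cc2[nH]c(=O)c(S(=O)(=O)c3ccccc3)cc21` gives 10.4% in an assay on isolated protein for inhibition of 3',5'-cyclic-AMP phosphodiesterase 4A (Cavia porcellus), read by cAMP accumulation, tested at 100 uM; a higher number here means a stronger effect of the compound at the concentration tested, a lower number a weaker effect. Compound 2 `CC(C)(C)C(=O)c1cc2c([nH]c1=O)CCCC2=O` gives 6.6% in this assay, a number that sits within the scatter of compound 1, so the two cannot be ordered. Compound 3 `CC(C)(C)C(=O)c1cc2c([nH]c1=O)CC(c1ccccc1)CC2=O` has not been measured. It differs from compound 2 by phenyl in place of hydrogen on a saturated ring carbon. Compound 1 already carries a phenyl on the same kind of ring carbon and stays low, so for compound 3 no step beyond the scatter is expected, with an estimated change of a number 1.4 percentage points higher from compound 2 to compound 3 (within the scatter). Compound 3 is thus expected near 8%, between 0% and 20%.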

Compound 3, a percentage reported as inhibition, at one concentration (the size of the read-out at that concentration, not a potency): 4.2%
The estimate for compound 3 lay 3.8 percentage points above the measured number; low and high end bracket the measured number.
By their numbers in this assay, from the lowest: compounds 3, 2 and 1 (each within the scatter of the next).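

Phenyl in place of hydrogen on a saturated ring carbon now has a direct reading in this assay with a number 2.4 percentage points lower from compound 2 to compound 3 (within the scatter) and so shows no step that can be separated from the scatter at this position. With that phenyl present in both compounds, (tert-butyl)carbonyl in place of phenylsulfonyl on an aromatic carbon gives a number 6.2 percentage points lower from compound 1 to compound 3 (within the scatter) and is likewise unresolved. No measurement at hand bears on a cause for either step. On these data alone, whether an amine or a carboxylic acid on the phenyl, or a longer chain on the carbonyl, would move the read-out beyond the scatter stays open.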